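Chain length in a hydroxycarbamoyl series: compound 2 to compound 3

The source may hold more compounds than are shown below. What is called first, only, known or untested is meant among the compounds shown, and "the series" means these compounds.

In a functional assay on PC-3 cells (Homo sapiens) for antiproliferative activity, read by MTT assay, with a stated time of 72 h (on this read-out higher numbers stand for weaker inhibition and lower numbers for stronger inhibition), the measured compounds are:
- compound 1 (`O=C(CCCn1cc(-c2ncnc3[nH]ccc23)cn1)NO`): > 100000 nM (a limit, not a number)
- compound 2 (`O=C(CCCCCCCn1cc(-c2ncnc3[nH]ccc23)cn1)NO`): 12900 nM

Among the measured compounds shown here, compound 2 holds the only actual number so far in this assay and has nothing numeric to be ranked against. The entry for compound 1 is only a limit (the limit of > 100000 nM in this assay, at which 1 of the 2 values shown sits).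

Compound 3 (`O=C(CCCCCCCCCCn1cc(-c2ncnc3[nH]ccc23)cn1)NO`) carries 3-(hydroxycarbamoyl)propyl in place of hydroxycarbamoyl on a saturated chain carbon, seven bonds along the chain from an aromatic nitrogen.

For the measured compounds named here, one measured step bears on this, a change of the same kind: 4-(hydroxycarbamoyl)butyl in place of hydroxycarbamoyl, three bonds along the chain from an aromatic nitrogen (an at least 7.7-fold lower number from compound 1 to compound 2 (0.88 log units; beyond the scatter)). As far as these compounds go, that step lies beyond the scatter, but it starts from a limit, so its true size stays open. A single step sets no trend. The expected step is therefore modest, toward lower numbers, and may stay within the scatter (a 1.6-fold lower number from compound 2 to compound 3 (0.21 log units; within the scatter)). For compound 3 the estimate is 8000 nM with an expected range from 2000 nM to 40000 nM in this read-out.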

Compound 3, half-maximal inhibitory concentration: 54300 nM
The estimate for compound 3 lay 6.8-fold (0.83 log units) below the measured number, and the stated range ends below it.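

In this assay, the change to 3-(hydroxycarbamoyl)propyl in place of hydroxycarbamoyl on a saturated chain carbon, seven bonds along the chain from an aromatic nitrogen, gives a 4.2-fold higher number from compound 2 to compound 3 (0.62 log units; beyond the scatter), whereas the earlier chain extension gave an at least 7.7-fold lower number from compound 1 to compound 2 (0.88 log units; beyond the scatter). Lengthening the chain therefore does not move the read-out in one direction across these three compounds: the number falls with the first extension and rises with the second, leaving compound 2 with the lowest number of the set. The entry for compound 1 is a limit and not a number, so the first step has no fixed size and only its direction can be read: the limit of > 100000 nM in this assay, at which 1 of the 3 values shown sits.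

The compounds shown leave open whether a chain of intermediate length between those of compound 2 and compound 3 gives a lower number than compound 2, and whether a still longer chain continues the rise. They also cannot show why the number rises, or whether a carboxylic acid or a primary amide in place of hydroxycarbamoyl follows the same dependence on chain length.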